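The source may hold more compounds than are shown below. What is called first, only, known or untested is meant among the compounds shown, and "the series" means these compounds.

Compound 1 `C#CCn1cc(C(=O)NC(CC(=O)Nc2ccccc2)c2ccccc2)c(=O)c2cc(F)c(Cl)nc21` was tested in a functional assay on ECV-304 cells (Homo sapiens) for cytotoxicity, read by MTT assay, with a stated time of 72 h; a higher number here means a weaker inhibitor, a lower number a stronger inhibitor. In this assay compound 1 gives only > 10000 nM, which is a limit of the assay and not a number. Two other compounds share most of its build. Compound 2 `C#CCn1cc(C(=O)NC(CC(=O)Nc2ccccc2)c2ccccc2)c(=O)c2cccnc21` differs in the core, and in this assay compound 2 likewise gives > 10000 nM, again a limit rather than a number. Compound 3 `C#CCn1cc(C(=O)NC(CC(=O)NC2CCCC2)c2ccccc2)c(=O)c2ccc(Cl)nc21` differs both in the core and in the group on the amide-type nitrogen, and in this assay compound 3 gives 7800 nM. Compound 1 thus stands at the limit of > 10000 nM in this assay, at which 2 of the 3 values shown sit, and with only a limit for it, its distance from compound 3 cannot be stated. Compound 4 `C#CCn1cc(C(=O)NC(CC(=O)Nc2ccccn2)c2ccccc2)c(=O)c2cc(F)c(Cl)nc21` is the next compound to be measured. It differs from compound 1 in one place: pyridin-2-yl in place of phenyl on an amide-type nitrogen. Among the measured compounds shown here, no measured pair shows this change, so nothing sets the size of the step. The expected step from compound 1 to compound 4 is a step that the limit leaves unreadable from compound 1 to compound 4, meaning no movement beyond the scatter. Compound 4 is expected to give about 12000 nM, in a range from 5000 nM to 30000 nM, and most likely it will again be reported only as a limit.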

Compound 4, half-maximal inhibitory concentration: > 10000 nM
Compound 4: only a limit was reported (the forecaster's own chance of this, stated with the estimate: 70%); the middle value does not contradict the limit.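

In this assay compound 4 gives > 10000 nM, a limit of the assay and not a number. Among the compounds shown here, compound 1 also has only a limit, so no step between compound 1 and compound 4 can be read. The compounds shown leave open whether pyridin-2-yl in place of phenyl on an amide-type nitrogen changes cytotoxicity at all.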